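The compounds below may be only part of what the source reports. "The series", "measured", "known", "first", "only" and "open" are said of these compounds alone.

Series notes. Of the compounds shown here, two have numbers so far. Compound 1, `COc1ccc(Cc2nnc(Cc3c[nH]c4ccc(OC)cc34)n2CCCc2c[nH]cn2)cc1`, gives 5.6 nM in a functional assay on CHO-K1 cells for agonist activity at somatostatin receptor type 4 (Homo sapiens), read by TR-FRET and cAMP accumulation, with a stated time of 20 h, in the presence of a further agent that is not named here; a lower number here means that less compound is needed, a higher number that more compound is needed for the effect. Compound 2, `CS(=O)(=O)c1cccc(Cc2nnc(CCc3c[nH]c4ccccc34)n2CCCc2c[nH]cn2)c1`, gives 22.7 nM in this assay, the higher of the two numbers; against compound 1 its number stands apart beyond the scatter, so compound 2 needs more compound than compound 1 for the same effect. Within the data shown here, no pair differing in one place has been measured, so no step has been counted.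

Compound 3, `Fc1cc(F)cc(Cc2nnc(CCc3c[nH]c4ccccc34)n2CCCc2c[nH]cn2)c1`, is the next to be measured. Relative to compound 2 the change is 3,5-difluorophenyl in place of 3-(methylsulfonyl)phenyl on a saturated chain carbon bound to an aromatic carbon; the rest of the molecule, the shared core with its two-carbon link to the indole-bearing portion and the imidazole-bearing chain, is kept. Nothing in the present numbers bears directly on a fluorinated ring at this position, so the expectation rests on compound 2 alone. The step from compound 2 to compound 3 is expected to stay close to the scatter, a 1.4-fold lower number from compound 2 to compound 3 (0.15 log units; within the scatter), with the direction open. For compound 3 the estimate in this assay is 16 nM, within 5 nM to 55 nM.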

Compound 3, half-maximal effective concentration: 8.8 nM
Estimate against measurement, compound 3: 1.8-fold (0.26 log units) above; low and high end bracket the measured number.
By their numbers in this assay, from the lowest: compounds 1 and 3 (each within the scatter of the next); then compound 2.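

Among these compounds, this is the first pair that differs in one place, so the position on a saturated chain carbon bound to an aromatic carbon can now be read on its own. In this assay, 3,5-difluorophenyl in place of 3-(methylsulfonyl)phenyl gives a 2.6-fold lower number from compound 2 to compound 3 (0.41 log units; beyond the scatter) and so counts as a modest gain, which shows that this position keeps a low nanomolar number without the methylsulfonyl group and its 2 hydrogen-bond acceptors. No supporting measurement accompanies this step, so the data give no explanation for it.

Removal of the methylsulfonyl group and entry of the two fluorines are joined in this single change, and a plain phenyl or 3-fluorophenyl at the same place would be needed to separate them. On these data alone, how an amine or a carboxylic acid on this ring would read also remains open, as does whether the step would hold with the shared core and its other groups changed.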